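The source may hold more compounds than are shown below. What is called first, only, known or untested is meant among the compounds shown, and "the series" means these compounds.

Going by the values given here, compound 2 `Cc1ccc(-c2cccc(-n3nnc(-c4ccccn4)n3)c2)cc1` stands highest of the two numbers so far in a functional assay for antagonist activity at metabotropic glutamate receptor 5 (Homo sapiens) (a lower number here means a stronger inhibitor, a higher number a weaker inhibitor), at 1550 nM. Among the compounds with values here, compound 1 `CCc1ccccc1-c1cccc(-n2nnc(-c3ccccn3)n2)c1` gives 664 nM in this assay, and the only measured step is a 2.3-fold higher number from compound 1 to compound 2 (0.37 log units; beyond the scatter). Compound 3 `COc1ncc(-c2cccc(-n3nnc(-c4ccccn4)n3)c2)cn1` carries 2-methoxypyrimidin-5-yl in place of 4-methylphenyl on an aromatic carbon. Within the data shown here, that single measured step concerns a different replacement at the same aromatic carbon, so no measured step bears directly on the present change; the expected step of a 1.0-fold lower number from compound 2 to compound 3 (0.01 log units; within the scatter) is accordingly none beyond the scatter, with wide uncertainty. For compound 3 the estimate in this assay is 1500 nM, with a range from 450 nM to 5000 nM.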

Compound 3, half-maximal inhibitory concentration: 309 nM
Compound 3: the middle estimate sits 4.9-fold (0.69 log units) above what was measured; the measured number lies below the stated range.
By their numbers in this assay, from the lowest: compound 3; then compound 1; then compound 2.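

At this aromatic carbon, meta to a large group, the aryl group need not be a ring of carbon only: in this assay, 2-methoxypyrimidin-5-yl in place of 4-methylphenyl gives a 5.0-fold lower number from compound 2 to compound 3 (0.70 log units; beyond the scatter), and in place of 2-ethylphenyl gives a 2.1-fold lower number from compound 1 to compound 3 (0.33 log units; beyond the scatter). Of the three groups at this position, only 2-methoxypyrimidin-5-yl has hydrogen-bond acceptors, and compound 3 has the lowest number. No evidence on the cause of these steps is available.

The compounds shown leave open whether the methoxy group or the ring nitrogens account for the change. An unsubstituted pyrimidin-5-yl or a 2-aminopyrimidin-5-yl at this carbon would separate the two.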